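The source may report more compounds than this note shows. Statements on the series, on what has been measured and on what is new or still open speak of the compounds shown alone.

Measured so far:
- compound 1 `O=C(/C=C/c1ccco1)c1ccc(NC(=O)c2cccs2)cc1`: 93000 nM in a toxicity assay on FHC cells (Homo sapiens) for cytotoxicity, read by resazurin assay, with a stated time of 48 h; a lower number here means that less compound is tolerated, a higher number that more compound is tolerated
- compound 2 `CC(=O)Nc1ccc(C(=O)/C=C/c2cccc([N+](=O)[O-])c2)cc1`: 15000 nM in this assay

Compound 2 gives the lowest number of the two in this assay; compound 1 sits higher, and the gap between the two values lies beyond the scatter. Within the data shown here, no single-point step links them, as they differ in two places, so the pair only shows that compound 1 is tolerated at a higher concentration than compound 2.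

Compound 3 `O=C(/C=C/c1cccc([N+](=O)[O-])c1)c1ccc(NC(=O)c2cccs2)cc1` is not yet measured. It departs from compound 2 by one change: thiophen-2-yl in place of methyl on a carbonyl carbon. The group that enters is the same amide portion carried by compound 1. Nothing in the measured pair isolates this change, so the step in this assay is expected to be modest, most likely within the scatter or a slight rise toward the value of compound 1. Compound 3 is therefore estimated at 22000 nM (range 7000 nM to 65000 nM), a step of a 1.5-fold higher number from compound 2 to compound 3 (0.17 log units; within the scatter) expected from the change.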

Compound 3, half-maximal cytotoxic concentration: 73000 nM
For compound 3 the middle estimate is 3.3-fold (0.52 log units) below the measured one; the measured number lies above the stated range.
By their numbers in this assay, from the lowest: compound 2; then compounds 3 and 1 (each within the scatter of the next).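

In this assay, thiophen-2-yl in place of methyl on a carbonyl carbon bound to the amide-type nitrogen gives a 4.9-fold higher number from compound 2 to compound 3 (0.69 log units; beyond the scatter), so this position alone moves the number beyond the scatter, which the earlier pair could not show. The other change, 3-nitrophenyl in place of furan-2-yl on the double-bonded chain carbon, gives a 1.3-fold lower number from compound 1 to compound 3 (0.11 log units; within the scatter), so of the two places separating compound 1 and compound 2, only the carbonyl position shows a step beyond the scatter, with the thiophen-2-yl amide held constant in the second comparison. No measurement here bears on why the number shifts.

As far as these compounds go, it remains open whether this step is specific to thiophen-2-yl or would also follow from phenyl, a longer alkyl chain or a simple amine on the same carbonyl carbon. From the compounds shown here alone, it is also open whether the exchange of furan-2-yl and 3-nitrophenyl stays as small with the acetamido group in place.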